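This account rests on a few compounds, and the source may have more. Where it says the series, first, only, none or still open, it means among the compounds named here.

Compound 1, `CCn1c(/C=C2/C(=O)Nc3ccccc32)nc2ccccc21`, gives > 50000 nM in a functional assay on HGC cells (Homo sapiens) for cytotoxicity, read by MTT assay, with a stated time of 48 h (on this read-out lower numbers stand for stronger inhibition and higher numbers for weaker inhibition), and this is a limit of the assay, not a number. Compound 2, `CCn1c(/C=C2/C(=O)Nc3ccc(Br)cc32)nc2ccccc21`, gives > 50000 nM in this assay, which is again a limit. Compound 2 therefore has no exact value to build on. Compound 3, `CCn1c(/C=C2/C(=O)Nc3ccc(Cl)cc32)nc2ccccc21`, differs from it by chloro in place of bromo on an aromatic carbon. Among the measured compounds shown here, the one measured step that bears on this change is a step that the two limits leave unreadable from compound 1 to compound 2, which brought in the bromo group that now leaves. It offers no readable size to carry over. Compound 1 and compound 2 both stand at the limit of > 50000 nM in this assay, at which 2 of the 2 values shown sit, so no clear change is expected in this assay. The expected result is a number no higher from compound 2 to compound 3 (the limit leaves the size open), with no move in either direction beyond the usual scatter. For compound 3 the estimated value is 50000 nM, with an expected range from 20000 nM to 100000 nM.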

Compound 3, half-maximal inhibitory concentration: > 50000 nM
Compound 3: only a limit was reported (the forecaster's own chance of this, stated with the estimate: 75%); the middle value lies on the limit itself.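

Compound 1, compound 2 and compound 3 all return a limit rather than a number, so no step among them can be read: the limit of > 50000 nM in this assay, at which 3 of the 3 values shown sit.

As far as these compounds go, how bromo, chloro or hydrogen at this place compare in this assay stays open, as does what on these compounds would bring a measurable value.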